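One More Carbon on the Charged Ring's Side Chain

A few compounds are considered here, and "the series" means these few. Any claim that something is new, unique, unknown or untested is made for them only; others in the source may bear on it.

Of the compounds shown here, two sharing one core have been measured in an assay on LX2 cells for inhibition of COL1A1 promoter (Homo sapiens), read by a luciferase reporter, with a stated time of 24 h, tested at 50 uM; a lower number here means a weaker effect, a higher number a stronger effect of the compound at the concentration tested. Compound 1 `Cc1cc(-n2cc(C(=O)Nc3cc(F)cc(F)c3)c(=O)c3ccc(N(C)C)nc32)ccc1OCCCCCCC[N+]12CCN(CC1)CC2` gives 20.8%. Going by the values given here, compound 2 `Cc1cc(-n2cc(C(=O)Nc3cc(F)cc(F)c3)c(=O)c3ccc(N(C)C)nc32)ccc1OCCCCCCC[N+]1(C)CCCCC1` gives 54.4%, the higher of the two numbers, and the single measured step, a number 33.6 percentage points higher from compound 1 to compound 2 (beyond the scatter), exchanges one charged ring system for another and is the only comparison available. Compound 3 `CC[N+]1(CCCCCCCOc2ccc(-n3cc(C(=O)Nc4cc(F)cc(F)c4)c(=O)c4ccc(N(C)C)nc43)cc2C)CCCCC1` is the next candidate. It differs from compound 2 by methyl in place of hydrogen on a saturated chain carbon bound to an amine nitrogen in a ring, a far smaller alteration than the exchange of ring systems seen in a number 33.6 percentage points higher from compound 1 to compound 2 (beyond the scatter). Among the compounds with values here, no measured step touches this particular spot, so the large step between compound 1 and compound 2 offers no direct guide, and adding a single carbon to the chain on the charged ring is not expected to move the number much. The expected step in this assay is therefore small, a number 2.4 percentage points lower from compound 2 to compound 3 (within the scatter), within the usual scatter in either direction. Compound 3 is estimated to give 52% in this assay, with a range from 30% to 72%.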

Compound 3, a percentage reported as inhibition, at one concentration (the size of the read-out at that concentration, not a potency): 53.4%
For compound 3 the middle estimate is 1.4 percentage points below the measured one; measured number inside the range.
By their numbers in this assay, from the lowest: compound 1; then compounds 3 and 2 (each within the scatter of the next).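

In this assay, the step from methyl to ethyl, printed as methyl in place of hydrogen on a saturated chain carbon bound to an amine nitrogen in a ring, gives a number 1 percentage points lower from compound 2 to compound 3 (within the scatter) and so leaves the read-out unchanged within the scatter, which the earlier pair could not show because it exchanged whole ring systems. The large gap seen earlier also survives this change, with a number 32.6 percentage points higher from compound 1 to compound 3 (beyond the scatter) in the same assay, so compound 2 and compound 3 stand together, clearly apart from compound 1, and at this position the ring system matters far more in these three compounds than methyl versus ethyl. Nothing beyond these percentages is available to explain either result.

How far this spot stays undemanding is open, since a propyl, a benzyl or a 2-hydroxyethyl group in place of the ethyl could keep the number level or shift it. Each read-out also comes from a single concentration, so compound 2 and compound 3 may still differ in the size of their effect at lower concentrations, and a morpholine ring in place of the six-membered ring would test what the ring itself contributes.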